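The source may report more compounds than this note shows. Statements on the series, on what has been measured and on what is new or still open speak of the compounds shown alone.

Compound 1 `CO[C@H]1CC[C@H](Nc2cc(NCc3cnccc3C(F)(F)F)ncc2C#N)CC1`: 1100 nM
Compound 2 `CO[C@H]1CC[C@H](CNc2cc(NCc3cnccc3C(F)(F)F)ncc2C#N)CC1`: 330 nM
Compound 3 `N#Cc1cnc(NCc2cnccc2C(F)(F)F)cc1NC1CCOCC1`: 900 nM

In an assay on isolated protein for inhibition of protein kinase C theta type (Homo sapiens), read by TR-FRET, with a stated time of 2 h (on this read-out higher numbers stand for weaker inhibition and lower numbers for stronger inhibition), compound 3 holds the second highest of the three numbers; its nearest neighbour is compound 1, with a gap that lies within the scatter, while the step of a 2.7-fold higher number from compound 2 to compound 3 (0.44 log units; beyond the scatter) lies beyond it. Compound 4 `CC1(C)C[C@@H](Nc2cc(NCc3cnccc3C(F)(F)F)ncc2C#N)CC[C@H]1O` differs from compound 3 in one place: 4-hydroxy-3,3-dimethylcyclohexyl in place of oxan-4-yl on a nitrogen on an aromatic ring. The measured step that bears on this is a 1.2-fold lower number from compound 1 to compound 3 (0.09 log units; within the scatter), where exchanging oxan-4-yl for a 4-methoxycyclohexyl ring left the number unchanged within the scatter. The 4-hydroxy-3,3-dimethylcyclohexyl ring is expected to behave much the same, so the step of a 1.2-fold lower number from compound 3 to compound 4 (0.08 log units; within the scatter) is expected to stay within the scatter. Compound 4 is therefore estimated at 750 nM, with a range from 250 nM to 2200 nM.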

Compound 4, half-maximal inhibitory concentration: 120 nM
Beside the measured number, compound 4's estimate is 6.3-fold (0.80 log units) above it, and the stated range ends above it.
By their numbers in this assay, from the lowest: compound 4; then compound 2; then compounds 3 and 1 (each within the scatter of the next).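

For the compounds shown here, the group on this nitrogen matters more than the earlier compounds suggested: oxan-4-yl and 4-methoxycyclohexyl stayed within the scatter of each other, whereas 4-hydroxy-3,3-dimethylcyclohexyl gives a clearly lower number (a 7.5-fold lower number from compound 3 to compound 4 (0.88 log units; beyond the scatter); a 9.2-fold lower number from compound 1 to compound 4 (0.96 log units; beyond the scatter)). Going by these compounds alone, this ring also improves on (4-methoxycyclohexyl)methyl, the lowest number among the earlier compounds (a 2.8-fold lower number from compound 2 to compound 4 (0.44 log units; beyond the scatter)). Nothing available explains these steps.

From the compounds shown here alone, the hydroxy group and the two methyl groups enter together, so their separate contributions remain open. So does the result of an amine in place of the hydroxy group.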